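From an Ester to a Methylcarbamoyl Group

The compounds below may be only part of what the source reports. "The series", "measured", "known", "first", "only" and "open" are said of these compounds alone.

Three esters built on a shared core have been tested in a functional assay on PC-3 cells (Homo sapiens) for cytotoxicity, read by MTT assay, with a stated time of 72 h; a lower number here means a stronger inhibitor, a higher number a weaker inhibitor. Compound 1 (`COc1ccc(OC)c(C(=O)/C=C/c2ccc(C(=O)OC(C)C)cc2)c1`), the isopropyl ester, gives 6740 nM. Compound 2 (`COc1ccc(OC)c(C(=O)/C=C/c2ccc(C(=O)OCc3ccccc3)cc2)c1`), the benzyl ester, gives 18000 nM. Compound 3 (`COc1ccc(OC)c(C(=O)/C=C/c2ccc(C(=O)OCC=C(C)C)cc2)c1`) is the 3-methylbut-2-en-1-yl ester. Compound 3 stands at > 50000 nM, which is a limit of the assay and not a number.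

Compound 4 (`CNC(=O)c1ccc(/C=C/C(=O)c2cc(OC)ccc2OC)cc1`) has not yet been measured. It has methylamino in place of (3-methylbut-2-en-1-yl)oxy on a carbonyl carbon. Put another way, ((3-methylbut-2-en-1-yl)oxy)carbonyl becomes methylcarbamoyl.

Among the measured compounds shown here, three measured steps bear on this change, though each only swaps one ester group for another. They are a 2.7-fold higher number from compound 1 to compound 2 (0.43 log units; beyond the scatter), an at least 7.4-fold higher number from compound 1 to compound 3 (0.87 log units; beyond the scatter) and an at least 2.7-fold higher number from compound 2 to compound 3 (0.44 log units; beyond the scatter). All three lie beyond the scatter, so changes in this part of the molecule have shifted the number by modest amounts or more. For the measured compounds named here, no measured compound carries methylcarbamoyl, so these steps suggest a likely size but do not settle the direction.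

The expected step is an at least 2.2-fold lower number from compound 3 to compound 4 (0.35 log units; beyond the scatter), a modest move towards a lower number, although the assay may again report only a limit. For compound 4 the estimated value is 22000 nM, with an expected range from 7000 nM to 70000 nM.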

Compound 4, half-maximal inhibitory concentration: 2130 nM
For compound 4 the middle estimate is 10-fold (1.01 log units) above the measured one; measured number outside the range, below it.
By their numbers in this assay, from the lowest: compound 4; then compound 1; then compound 2. At a limit, above all of these: compound 3.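

In this assay, methylamino gives a lower number than each of the three ester groups on this carbonyl carbon, with a 3.2-fold lower number from compound 1 to compound 4 (0.50 log units; beyond the scatter), an 8.5-fold lower number from compound 2 to compound 4 (0.93 log units; beyond the scatter) and an at least 23-fold lower number from compound 3 to compound 4 (1.37 log units; beyond the scatter). Among the compounds shown here, the earlier compounds showed only that the number shifts from one ester to another, whereas this change shows that the position can leave the ester series altogether and still go below the best ester, compound 1. Compound 3 stands at a limit of the assay and not at a number, so its step gives only a minimum size: the limit of > 50000 nM in this assay, at which 1 of the 4 values shown sits.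

Which feature of methylamino goes with the lower number stays open, as this one swap changes the atom bound to the carbonyl carbon, the length of the group and the presence of the amide hydrogen all at once. Dimethylamino, which has no amide hydrogen, and ethylamino, which has a longer chain on the nitrogen, would begin to pull these apart, while a carboxylic acid on the same carbonyl carbon would test a different kind of group there.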